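Swapping Trifluoromethyl for Chloro on the Urea Aryl Ring

The compounds below may be only part of what the source reports. "The series", "measured", "known", "first", "only" and "open" are said of these compounds alone.

Of the compounds shown here, two sharing one core have been measured in a functional assay on U-251 cells (Homo sapiens) for inhibition, read by sulforhodamine B assay, with a stated time of 48 h; on this read-out higher numbers stand for weaker inhibition of growth and lower numbers for stronger inhibition of growth. Compound 2 `COc1cc2cc(Oc3ccc(NC(=O)Nc4ccc(Cl)c(C(F)(F)F)c4)cc3)c(C)nc2cc1OC` gives 3780 nM in this assay, and compound 1 `COc1cc2cc(Oc3ccc(NC(=O)Nc4cccc(C(F)(F)F)c4)cc3)c(C)nc2cc1OC` gives 5610 nM. The step of a 1.5-fold lower number from compound 1 to compound 2 (0.17 log units; within the scatter) separates them, and that gap lies within the scatter, so the two numbers are on a par rather than ranked. Compound 3 `COc1cc2cc(Oc3ccc(NC(=O)Nc4ccc(Cl)c(Cl)c4)cc3)c(C)nc2cc1OC` has not been measured. It differs from compound 2 by chloro in place of trifluoromethyl on an aromatic carbon. Among the compounds with values here, the only measured step, a 1.5-fold lower number from compound 1 to compound 2 (0.17 log units; within the scatter), concerns the same ring but exchanges different groups, so it bears on the new change only loosely; what it shows is that one substitution on this ring moved the number little. Within the data shown here, no measured pair exchanges trifluoromethyl for chloro, so direct precedent is missing and the range must be wide. The expectation for compound 3 in this assay is a step of about a 1.3-fold higher number from compound 2 to compound 3 (0.12 log units; within the scatter), which is no change beyond the scatter. Compound 3 is estimated at 5000 nM, with a range from 1800 nM to 14000 nM.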

Compound 3, concentration for total growth inhibition: 7260 nM
The estimate for compound 3 lay 1.5-fold (0.16 log units) below the measured number; the range from low to high includes it.
By their numbers in this assay, from the lowest: compounds 2, 1 and 3 (each within the scatter of the next).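

In this assay, within the data shown here, the step of a 1.9-fold higher number from compound 2 to compound 3 (0.28 log units; within the scatter) is the first direct look at trifluoromethyl giving way to chloro on this aromatic carbon, ortho to a chloro group, and it lies within the scatter, so a group of one heavy atom and a group of four heavy atoms are not told apart here. The step of a 1.3-fold higher number from compound 1 to compound 3 (0.11 log units; within the scatter) also lies within the scatter, which means that 3,4-dichlorophenyl and 3-(trifluoromethyl)phenyl on the urea nitrogen stand on a par as well, and all three listed steps between these compounds now sit inside the usual spread of repeated measurements. No measurement at hand offers an explanation for these numbers.

From the compounds shown here alone, all three compounds carry only trifluoromethyl or chloro on this ring, so it remains open whether a different group at this carbon, such as a methoxy group, an amine or a carboxylic acid, would move the number beyond the scatter. Going by these compounds, it also remains open whether changes to the shared core would matter more than changes to this ring.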